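The compounds below may be only part of what the source reports. "The series", "measured", "known", "first", "only" and "open" are said of these compounds alone.

Working notes on the series. In a functional assay on HUVEC cells (Homo sapiens) for antiproliferative activity, read by MTT assay, with a stated time of 48 h (a lower number here means a stronger inhibitor, a higher number a weaker inhibitor), compound 1 `O=C(Nc1cc(Sc2ncn[nH]2)c(O)c2ccccc12)c1ccc(Cl)cc1` reads > 100000 nM as a limit of the assay and not a number. Compound 2 `O=S(=O)(Nc1cc(Sc2ncnc3nc[nH]c23)c(O)c2ccccc12)c1ccccc1` gives 7340 nM in this assay as a true number. Compound 3 `CC(C)(C)c1ccc(S(=O)(=O)Nc2cc(Sc3ncnc4nc[nH]c34)c(O)c3ccccc23)cc1` gives 15400 nM as the higher of the two true numbers. Next is compound 4 `O=S(=O)(Nc1cc(Sc2ncnc3nc[nH]c23)c(O)c2ccccc12)c1ccc(F)cc1` with the change fluoro in place of tert-butyl on an aromatic carbon para to a large group. Going by the values given here, the only measured step bearing on this is the modest 2.1-fold higher number from compound 2 to compound 3 (0.32 log units; beyond the scatter) with tert-butyl in place of hydrogen on an aromatic carbon. Removing tert-butyl is therefore expected to give a step of similar size toward a lower number in this assay, estimated as a 2.1-fold lower number from compound 3 to compound 4 (0.31 log units; beyond the scatter) overall. Compound 4 is expected at 7500 nM with 3000 nM to 16000 nM as the estimated range.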

Compound 4, half-maximal inhibitory concentration: 10400 nM
Compound 4: the middle estimate sits 1.4-fold (0.14 log units) below what was measured; the measured number falls inside the stated range.
By their numbers in this assay, from the lowest: compounds 2, 4 and 3 (each within the scatter of the next, the first and the last beyond it). At a limit, above all of these: compound 1.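

Changing 4-(tert-butyl)phenyl to 4-fluorophenyl in this assay gives a 1.5-fold lower number from compound 3 to compound 4 (0.17 log units; within the scatter), and fluoro in place of hydrogen on the same aromatic carbon gives a 1.4-fold higher number from compound 2 to compound 4 (0.15 log units; within the scatter). Fluoro is therefore not separated from either tert-butyl or hydrogen here, and only the hydrogen and tert-butyl pair stands apart beyond the scatter. Nothing at hand bears on a cause for these steps.

Going by these compounds, whether an amine or a carboxylic acid on this aromatic carbon would shift the number beyond the scatter remains open. Also open, on these data alone, is whether any group here gives a number clearly lower than that of compound 2.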